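This account rests on a few compounds, and the source may have more. Where it says the series, first, only, none or still open, it means among the compounds named here.

Three compounds have been measured in a functional assay on KYSE-410 cells (Homo sapiens) for antiproliferative activity, read by MTT assay, with a stated time of 72 h; a lower number here means a stronger inhibitor, a higher number a weaker inhibitor:

Compound 1 `O=C(Nc1ccc(Cl)cc1)c1cc(=O)[nH]c2cc(Br)ccc12` gives > 20000 nM
Compound 2 `COc1ccc2c(C(=O)Nc3cc(F)cc(F)c3)cc(=O)[nH]c2n1` gives > 20000 nM
Compound 3 `COc1ccc(-c2ccc3c(C(=O)Nc4cccc(F)c4)cc(=O)[nH]c3c2)cc1` gives 18000 nM

Compound 1 gives > 20000 nM, which is a limit of the assay and not a number. Compound 2 gives > 20000 nM, which is also a limit. Compound 1 and compound 2 therefore share (the limit of > 20000 nM in this assay, at which 2 of the 3 values shown sit). Among the compounds with values here, compound 3, at 18000 nM, holds the only actual number in this assay, so it is the sole numerical reference point in this small set.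

The next compound to be tested is compound 4 `O=C(Nc1cccc(F)c1)c1cc(=O)[nH]c2cc(-c3ccncc3)ccc12`. It carries pyridin-4-yl in place of 4-methoxyphenyl on an aromatic carbon, and the rest of compound 3 stays unchanged: pyridin-4-yl in place of 4-methoxyphenyl on an aromatic carbon. Within the data shown here, no measured pair in this set shows what an exchange of this kind does. A step within the usual scatter is therefore expected in this assay, with neither direction favoured. This expectation rests on compound 3 at 18000 nM. Compound 4 may also be reported only as a limit. The estimated change is a 1.1-fold lower number from compound 3 to compound 4 (0.05 log units; within the scatter). Compound 4 is expected at an estimated 16000 nM, within a range of 6000 nM to 35000 nM.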

Compound 4, half-maximal inhibitory concentration: > 20000 nM
Compound 4: no number, only a limit; the forecaster's own chance of this, stated with the estimate: 50%; middle value at least 1.2-fold (0.09 log units) away from the limit.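

In this assay, within the data shown here, pyridin-4-yl in place of 4-methoxyphenyl on this aromatic carbon gives the first step that can be read in this set, an at least 1.1-fold higher number from compound 3 to compound 4 (0.04 log units; that floor lies within the scatter). Going by these compounds, compound 4 gives > 20000 nM, which is a limit of the assay and not a number, so this step has only a floor and its real size stays unknown. The exchange does not bring a measurable number at this position, and compound 4 now stands with compound 1 and compound 2, leaving compound 3 as the only compound with an actual value: the limit of > 20000 nM in this assay, at which 3 of the 4 values shown sit.

On these data alone, how far compound 4 truly lies from compound 3 remains open, and so does whether the swap of a carbon-only aromatic ring for a ring with one hetero atom matters at all in this cell assay. Equally open, as far as these compounds go, is how a group of another kind on this aromatic carbon would read, such as a carboxylic acid, a dimethylamino group or a longer alkyl chain, and whether any of these would give a number clearly lower than that of compound 3.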